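Vero Cell Cytotoxicity: a Trifluorophenyl Analogue of Compound 2

The source may hold more compounds than are shown below. What is called first, only, known or untested is meant among the compounds shown, and "the series" means these compounds.

Measured so far:
- compound 1 `C[C@]1(CN2CCn3cc(-c4ccc(F)cc4)nc3C2)Cn2cc([N+](=O)[O-])nc2O1`: "not determined" (no result reported)
- compound 2 `C[C@]1(CN2CCc3nc(-c4ccc(C(F)(F)F)cc4)ccc3C2)Cn2cc([N+](=O)[O-])nc2O1`: > 32 ug/mL

In an ADME assay on Vero cells (Chlorocebus sabaeus) for cytotoxicity, read by MTT assay, with a stated time of 72 h (on this read-out lower numbers stand for higher toxicity in this test and higher numbers for lower toxicity in this test), compound 2 gives only a limit, > 32 ug/mL, and no number; this is the limit of > 32 ug/mL in this assay, at which 1 of the 2 values shown sits. Among the measured compounds shown here, for compound 1 no result is reported in this assay, so no step between measured compounds can be set out here.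

Compound 3 `C[C@]1(CN2CCc3nc(-c4cc(F)c(F)c(F)c4)ccc3C2)Cn2cc([N+](=O)[O-])nc2O1` differs from compound 2 by 3,4,5-trifluorophenyl in place of 4-(trifluoromethyl)phenyl on an aromatic carbon. For the measured compounds named here, since the one reported value for compound 2 is the limit (the limit of > 32 ug/mL in this assay, at which 1 of the 2 values shown sits), the step that the limit leaves unreadable from compound 2 to compound 3 is expected to be none beyond the scatter, and compound 3 is estimated at 40 ug/mL in this assay, between 16 ug/mL and 100 ug/mL, most likely again reported as a limit.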

Compound 3, half-maximal cytotoxic concentration: > 32 ug/mL
Compound 3: a limit, no number; the forecaster's own chance of this, stated with the estimate: 70%; the middle value lies beyond the limit too.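

No step can be read from compound 2 to compound 3 in this assay, since both compounds give a limit and no number: the limit of > 32 ug/mL in this assay, at which 2 of the 3 values shown sit.

The compounds shown leave open whether 3,4,5-trifluorophenyl and 4-(trifluoromethyl)phenyl differ at all in this assay.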